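The compounds below may be only part of what the source reports. "The series", "measured", "known", "first", "only" and "open" are said of these compounds alone.

Compound 3 `CCCCN(c1nc2c(C(=O)NS(C)(=O)=O)cccc2o1)[C@H](C)c1ccc(-c2ccccc2-c2nnn[nH]2)cc1` is measured in an ADME assay on the whole organism (Macaca fascicularis) for pharmacokinetics, read by LC-MS, using cassette dosing, at a dose of 1 mg/kg by the oral route (on this read-out higher numbers stand for higher exposure at the dose given and lower numbers for lower exposure), where it gives 40.4 nM. Among the three compounds with numbers, it stands second highest: its nearest neighbour is compound 1 `CCCCN(c1nc2ccccc2o1)[C@H](C)c1ccc(-c2ccccc2-c2nnn[nH]2)cc1`, which gives 29.2 nM, a gap within the scatter, and the furthest is compound 2 `CCCCN(c1nc2c(C(=O)O)cccc2o1)[C@H](C)c1ccc(-c2ccccc2-c2nnn[nH]2)cc1`, which gives 238 nM, a gap that is beyond the scatter.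

Compound 4 `CCCCN(c1nc2c(-c3ccccn3)cccc2o1)[C@H](C)c1ccc(-c2ccccc2-c2nnn[nH]2)cc1` is not yet measured. It differs from compound 3 in one place: pyridin-2-yl in place of (methylsulfonyl)carbamoyl on an aromatic carbon.

Three measured steps frame this change. From compound 1 to compound 3 the number changed by a 1.4-fold higher number from compound 1 to compound 3 (0.14 log units; within the scatter), so attaching the (methylsulfonyl)carbamoyl group to the core left exposure essentially where it was. From compound 1 to compound 2 the change was an 8.2-fold higher number from compound 1 to compound 2 (0.91 log units; beyond the scatter), and from compound 2 to compound 3 it was a 5.9-fold lower number from compound 2 to compound 3 (0.77 log units; beyond the scatter). For the measured compounds named here, no measured step introduces a pyridin-2-yl group or any ring at this position, so these steps bear on it only loosely: the one substituent that raised exposure was the carboxy group of compound 2, which compound 4 does not carry.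

On that basis the number for compound 4 is expected to sit close to those of compound 1 and compound 3, with a step of a 1.2-fold lower number from compound 3 to compound 4 (0.06 log units; within the scatter), giving an estimate of 35 nM within a range from 10 nM to 120 nM.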

Compound 4, maximal plasma concentration: 124 nM
Estimate against measurement, compound 4: 3.5-fold (0.55 log units) below; the whole stated range lies below it.
By their numbers in this assay, from the lowest: compounds 1 and 3 (each within the scatter of the next); then compounds 4 and 2 (each within the scatter of the next).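

For the compounds shown here, at this aromatic carbon, carboxy was previously the only group to move the number in this assay beyond the scatter, but compound 4 shows that a ring can do so too: putting pyridin-2-yl in place of hydrogen gives a 4.2-fold higher number from compound 1 to compound 4 (0.63 log units; beyond the scatter) on the shared core. The exchange of carboxy for pyridin-2-yl gives a 1.9-fold lower number from compound 2 to compound 4 (0.28 log units; within the scatter), so these two very different groups cannot be told apart on this read-out, even though pyridin-2-yl counts no hydrogen-bond donor and contains no carbonyl. The position is also shown to respond to which group replaces which, since exchanging (methylsulfonyl)carbamoyl for pyridin-2-yl gives a 3.1-fold higher number from compound 3 to compound 4 (0.49 log units; beyond the scatter), a step that separates two substituents of similar size in heavy atoms.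

No information at hand explains why these groups give different exposure. As far as these compounds go, it remains open whether the ring nitrogen matters, which a comparison of pyridin-2-yl with pyridin-3-yl or a plain phenyl ring at this same carbon would address, and whether a small amine would behave like either carboxy or hydrogen.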